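Urea aryl swap: from methylphenyl to chloro-trifluoromethylphenyl

The source may report more compounds than this note shows. Statements on the series, on what has been measured and on what is new or still open speak of the compounds shown alone.

Compound 1, `O=C(Nc1ccc(Oc2ccc(-c3ncc[nH]3)cc2)cc1)Nc1ccc(F)c(C(F)(F)F)c1`: 26.6%
Compound 2, `Cc1ccc(NC(=O)Nc2ccc(Oc3ccc(-c4ncc[nH]4)cc3)cc2)cc1`: 49.3%

Two ureas on a shared core have been measured in a functional assay on MDA-MB-231 cells (Homo sapiens) for inhibition, read by MTT assay and WST assay, with a stated time of 72 h, tested at 10 uM; a higher number here means more inhibition of growth at the concentration tested, a lower number less inhibition of growth. Compound 1 gives 26.6% and compound 2 gives 49.3%, which places compound 2 highest of the two, with a number 22.7 percentage points higher from compound 1 to compound 2 (beyond the scatter). Compound 3, `O=C(Nc1ccc(Oc2ccc(-c3ncc[nH]3)cc2)cc1)Nc1cc(C(F)(F)F)ccc1Cl`, carries 2-chloro-5-(trifluoromethyl)phenyl in place of 4-methylphenyl on an amide-type nitrogen. Among the measured compounds shown here, the only step that bears on it is a number 22.7 percentage points higher from compound 1 to compound 2 (beyond the scatter), which runs from a halogenated trifluoromethylphenyl to the methylphenyl; compound 3 moves back towards such a group, so a drop in this assay is expected, roughly a number 19.3 percentage points lower from compound 2 to compound 3 (beyond the scatter). Compound 3 is therefore estimated at 30%, in the range 10% to 52%.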

Compound 3, percent growth inhibition at one concentration: 32.3%
The estimate for compound 3 lay 2.3 percentage points below the measured number; the measured number falls inside the stated range.
By their numbers in this assay, from the lowest: compounds 1 and 3 (each within the scatter of the next); then compound 2.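

Replacing the 4-methylphenyl on the amide-type nitrogen in this assay gave a number 17 percentage points lower from compound 2 to compound 3 (beyond the scatter) and so showed that a second halogenated trifluoromethylphenyl also stands below compound 2. Changing one such group for the other gave a number 5.7 percentage points higher from compound 1 to compound 3 (within the scatter) and so did not separate 2-chloro-5-(trifluoromethyl)phenyl from 4-fluoro-3-(trifluoromethyl)phenyl. Nothing available explains the gap between these groups and the 4-methylphenyl. The compounds shown leave open whether the methyl itself matters, which an unsubstituted phenyl would test. They also leave open how a methoxy or an amine on this phenyl would compare.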